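The source may report more compounds than this note shows. Statements on the series, on what has been measured and on what is new or still open speak of the compounds shown alone.

Measured so far in a functional assay on HCT-116 cells (Homo sapiens) for antiproliferative activity, read by MTT assay, with a stated time of 72 h; a lower number here means a stronger inhibitor, a higher number a weaker inhibitor
- compound 1 `NC1=NC2(CCOCC2)N(OCCCOc2ccc(Cl)cc2)C(N)=N1` gives 690 nM
- compound 2 `NC1=NC2(CCOCC2)N(OCCCOc2ccc(Cl)cc2Cl)C(N)=N1` gives 880 nM

For the measured compounds named here, compound 2 stands level with the only other measured compound, its number lying within the scatter of that value. Compound 3 `NC1=NC2(CCOCC2)N(OCCCOc2ccccc2Br)C(N)=N1` keeps the shared core and the chain but changes the aromatic group of compound 2: 2-bromophenyl in place of 2,4-dichlorophenyl on an oxygen on a saturated carbon. Going by the values given here, the one measured step that bears on this change is a 1.3-fold higher number from compound 1 to compound 2 (0.11 log units; within the scatter), which is chloro in place of hydrogen on an aromatic carbon. Among the compounds with values here, no measured compound carries bromine, so the guide is thin. On that single small step, no change beyond the scatter is expected in this assay. The expected step is a 1.1-fold lower number from compound 2 to compound 3 (0.04 log units; within the scatter). For compound 3 the estimate is 800 nM, with an expected range of 300 nM to 2100 nM.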

Compound 3, half-maximal inhibitory concentration: 30 nM
Beside the measured number, compound 3's estimate is 27-fold (1.43 log units) above it; measured number outside the range, below it.
By their numbers in this assay, from the lowest: compound 3; then compounds 1 and 2 (each within the scatter of the next).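

In this assay the aromatic group on the oxygen on a saturated carbon turns out to be a sensitive place: 2-bromophenyl in place of 2,4-dichlorophenyl gives a 29-fold lower number from compound 2 to compound 3 (1.47 log units; beyond the scatter), and 2-bromophenyl in place of 4-chlorophenyl gives a 23-fold lower number from compound 1 to compound 3 (1.36 log units; beyond the scatter). The earlier step on this ring, a 1.3-fold higher number from compound 1 to compound 2 (0.11 log units; within the scatter), lay within the scatter, so the flat picture held only for the two chlorine-bearing groups. Nothing available accounts for the large steps.

Compound 3 loses all chlorine and gains bromine in a single change, so these compounds cannot tell whether the lower number follows the bromine or the loss of chlorine. Also open, as far as these compounds go, is how a plain phenyl group, a ring bearing a methoxy group or a longer chain would read in this assay.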